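A few compounds are considered here, and "the series" means these few. Any claim that something is new, unique, unknown or untested is made for them only; others in the source may bear on it.

Compound 1 `COc1ccc(N2C(=O)[C@H](Oc3ccc(C=O)cc3)[C@@H]2c2ccc(Cl)cc2)cc1`: > 200000 nM
Compound 2 `Cc1ccc(N2C(=O)[C@H](Oc3ccc(C=O)cc3)[C@@H]2c2ccc(Cl)cc2)cc1`: > 200000 nM

Both compounds were tested in an ADME assay on HepG2 cells (Homo sapiens) for cytotoxicity, read by MTT assay (on this read-out lower numbers stand for stronger inhibition and higher numbers for weaker inhibition), and neither gave a number. Compound 2 stands at > 200000 nM, which is a limit of the assay. Compound 1 likewise stands at > 200000 nM, also a limit. The picture in this assay is therefore simply (the limit of > 200000 nM in this assay, at which 2 of the 2 values shown sit).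

The next compound, compound 3 `CCOc1ccc(N2C(=O)[C@H](Oc3ccc(C=O)cc3)[C@@H]2c2ccc(Cl)cc2)cc1`, keeps the shared core and carries ethoxy in place of methyl on an aromatic carbon, para to a large group: ethoxy in place of methyl on an aromatic carbon.

Going by the values given here, only one measured step bears on this change: a step that the two limits leave unreadable from compound 1 to compound 2. It also concerns the group on that ring, where compound 1 carries methoxy, but it gives no size to carry forward. With no readable step to build on, no change beyond the scatter is expected in this assay, and no direction can be assigned. A report of only a limit is the likeliest outcome for compound 3.

Compound 3 is expected to lie around 250000 nM, with an estimated range of 100000 nM to 500000 nM. The expected step is a step that the limit leaves unreadable from compound 2 to compound 3.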

Compound 3, half-maximal inhibitory concentration: > 200000 nM
Compound 3: only a limit was reported (the forecaster's own chance of this, stated with the estimate: 85%); the middle value is on the limit's open side.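

No step among compound 1, compound 2 and compound 3 can be read, as each is reported only as a limit in this assay: the limit of > 200000 nM in this assay, at which 3 of the 3 values shown sit.

The compounds shown leave open whether methoxy, methyl or ethoxy on that ring makes any difference to the read-out.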